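Replacing the 4-chlorophenyl group of compound 1

The source may report more compounds than this note shows. Statements on the series, on what has been measured and on what is new or still open speak of the compounds shown alone.

Measured so far in a functional assay on HeLa cells (Homo sapiens) for inhibition, read by MTT assay, with a stated time of 72 h (on this read-out higher numbers stand for weaker inhibition and lower numbers for stronger inhibition), are two compounds:
Compound 1 `COc1cc(OC)c(OC)cc1/C=C/C(=O)c1ccc(Cl)cc1` gives 36500 nM in this test
Compound 2 `COc1cc(OC)c(OC)cc1/C=C/C(=O)c1ccc(Cl)c([N+](=O)[O-])c1` gives 16500 nM in this test

Of the two, compound 1 stands highest at 36500 nM and is the weaker inhibitor. Compound 3 `COc1cc(OC)c(OC)cc1/C=C/C(=O)c1cc(O)ccc1O` has not yet been measured and differs from compound 1 by 2,5-dihydroxyphenyl in place of 4-chlorophenyl on a carbonyl carbon in one place, with 2,5-dihydroxyphenyl in place of 4-chlorophenyl on a carbonyl carbon. Among the measured compounds shown here, the only measured step that bears on this is a 2.2-fold lower number from compound 1 to compound 2 (0.34 log units; beyond the scatter) on the ring that leaves, and it is modest. For the measured compounds named here, no measured compound carries hydroxy groups, so this guide is loose and the range must stay wide. A modest move toward a lower number is expected. The estimated step is a 2.0-fold lower number from compound 1 to compound 3 (0.31 log units; beyond the scatter) in this assay and remains uncertain. For compound 3 the expected value is 18000 nM with an estimated range from 5000 nM to 60000 nM until it is measured.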

Compound 3, half-maximal inhibitory concentration: > 150000 nM
Compound 3: no number, only a limit; the forecaster's own chance of this, stated with the estimate: 10%; middle value at least 8.3-fold (0.92 log units) away from the limit.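

For compound 3 the result is a limit of the assay and not a number: the limit of > 150000 nM in this assay, at which 1 of the 3 values shown sits.

Exchanging 4-chlorophenyl for 2,5-dihydroxyphenyl on the carbonyl carbon gives an at least 4.1-fold higher number from compound 1 to compound 3 (0.61 log units; beyond the scatter) in this assay, so a change to the ring at this place can weaken inhibition, which the earlier pair did not show. On these data alone, this step, whose full size stays unknown, runs opposite to a 2.2-fold lower number from compound 1 to compound 2 (0.34 log units; beyond the scatter), where a nitro group takes the place of a hydrogen on the aromatic ring.

Since the chlorine leaves and both hydroxy groups enter in one step, the compounds shown do not tell which of these changes accounts for the loss. As far as these compounds go, whether a single hydroxy group or an amine on this ring would keep inhibition close to that of compound 1 also stays open.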